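A few compounds are considered here, and "the series" means these few. Any claim that something is new, unique, unknown or untested is made for them only; others in the source may bear on it.

Measured so far:
compound 1, `O=C(/C=C/c1ccc(/C=C/C(=O)c2ccc3ccccc3c2)o1)NO`, 4380 nM
compound 2, `COc1cc(/C=C/c2ccc(C(=O)NO)o2)ccc1OCc1ccccc1`, 10300 nM
compound 3, `O=C(/C=C/c1ccc(/C=C/C(=O)c2cccc(Cl)c2)o1)NO`, 12900 nM

These three compounds were examined in an assay on isolated protein for inhibition of histone deacetylase 4 (Homo sapiens), read by fluorescence; on this read-out higher numbers stand for weaker inhibition and lower numbers for stronger inhibition. In this assay compound 3 gives 12900 nM. Its nearest neighbour among the three is compound 2, whose number lies within the scatter of that of compound 3, so the two cannot be told apart on these data. Compound 1, with a lower number, sits beyond the scatter from compound 3, and is the one of the three that stands furthest away from it.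

Compound 4 is `O=C(/C=C/c1ccc(/C=C/C(=O)c2ccc(Cl)cc2)o1)NO`, not yet measured in this assay. It differs from compound 3 in one place: 4-chlorophenyl in place of 3-chlorophenyl on a carbonyl carbon. Within the data shown here, no pair of measured compounds shows this kind of move, so there is no step in this set to lean on. On that basis a step beyond the scatter is not expected, in either direction. The step expected here, a 1.3-fold lower number from compound 3 to compound 4 (0.11 log units; within the scatter), is therefore a small one. Compound 4 is estimated to give 10000 nM, with a range from 4000 nM to 30000 nM.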

Compound 4, half-maximal inhibitory concentration: 6030 nM
Estimate against measurement, compound 4: 1.7-fold (0.22 log units) above, and the stated range covers the measured number.
By their numbers in this assay, from the lowest: compounds 1, 4, 2 and 3 (each within the scatter of the next, the first and the last beyond it).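

In this assay, the place of the chlorine on the phenyl ring attached to the carbonyl carbon proves to matter: 4-chlorophenyl in place of 3-chlorophenyl gives a 2.1-fold lower number from compound 3 to compound 4 (0.33 log units; beyond the scatter), a modest step but one beyond the scatter. Among these compounds, this is the first step in the set that can be read between two compounds differing in one place, and it shows that this part of the molecule does not tolerate every arrangement equally. The leaving and entering groups have the same heavy atoms, the same aromatic ring and the same count of hydrogen-bond donors and acceptors, so the change lies only in how the atoms are joined, and nothing available explains why the number moves in this direction.

The compounds shown leave open whether the advantage of 4-chlorophenyl over 3-chlorophenyl carries over to other groups at this place, such as 4-methoxyphenyl, 4-fluorophenyl or unsubstituted phenyl. They also leave open how a basic amine, such as dimethylamino, or a carboxylic acid on this phenyl ring would compare with the chlorine of compound 4 in this assay.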